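The source may hold more compounds than are shown below. What is called first, only, known or untested is meant among the compounds shown, and "the series" means these compounds.

Going by the values given here, compound 2 `COc1ccc(CCCNCc2c(OC)cc(Oc3cccc(Nc4ccccc4)c3)cc2OC)cc1` sits at the higher end of the two numbers so far in a functional assay on DLD-1 cells (Homo sapiens) for inhibition, read by MTT assay, with a stated time of 72 h (a lower number here means a stronger inhibitor, a higher number a weaker inhibitor), where compound 2 gives 2540 nM; compound 1 `COc1ccc(CNCc2c(OC)cc(Oc3cccc(Nc4ccccc4)c3)cc2OC)cc1` gives 1910 nM in this assay, and the gap between the two, a 1.3-fold higher number from compound 1 to compound 2 (0.12 log units; within the scatter), is within the scatter. Compound 3 `COc1cc(Oc2cccc(Nc3ccccc3)c2)cc(OC)c1CNCc1ccc(Br)cc1` takes the step (4-bromophenyl in place of 2-(4-methoxyphenyl)ethyl on a saturated chain carbon bound to an amine nitrogen). Among the compounds with values here, the only measured step that bears on it is the chain-length change, a 1.3-fold higher number from compound 1 to compound 2 (0.12 log units; within the scatter), which made no difference beyond the scatter; the swap of a methoxy-bearing ring for a bromine-bearing ring has no precedent in this set, so nothing here argues for a step beyond the scatter in either direction. The expected step is therefore a 1.2-fold lower number from compound 2 to compound 3 (0.08 log units; within the scatter), a number close to that of compound 2. For compound 3 the estimate in this assay is 2100 nM, with a range from 800 nM to 5500 nM to cover the untested ring substituent.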

Compound 3, half-maximal inhibitory concentration: 3520 nM
The estimate for compound 3 lay 1.7-fold (0.22 log units) below the measured number; measured number inside the range.
By their numbers in this assay, from the lowest: compounds 1, 2 and 3 (each within the scatter of the next).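

At the saturated chain carbon bound to an amine nitrogen, 4-bromophenyl in place of 2-(4-methoxyphenyl)ethyl gives (a 1.4-fold higher number from compound 2 to compound 3 (0.14 log units; within the scatter)) in this assay, although the ring substituent and the chain length change together in this step. Bromo in place of methoxy on an aromatic carbon, a change in one group alone, gives (a 1.8-fold higher number from compound 1 to compound 3 (0.27 log units; within the scatter)), so this swap also stays within the scatter and the three compounds cannot be told apart at this position. No measurement is available that would account for these numbers.

A 3-(4-bromophenyl)propyl group on the amine nitrogen would separate the effects of chain and ring substituent that are combined in the step to compound 3. On these data alone, whether any group on this aromatic carbon moves the number beyond the scatter remains open, for instance a hydroxyl, a nitrile or a carboxylic acid.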